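The source may report more compounds than this note shows. Statements on the series, on what has been measured and on what is new or still open speak of the compounds shown alone.

Going by the values given here, compound 3, `C[Se]/C(=N\C(=O)c1cccs1)NC(=O)c1cccs1`, has the lowest number among the three compounds measured so far in a functional assay on MCF7 cells (Homo sapiens) for cytotoxicity, read by MTT assay, with a stated time of 72 h; on this read-out lower numbers stand for stronger inhibition of growth and higher numbers for weaker inhibition of growth. Its value of 3.4 nM lies well apart from compound 2, `C[Se]/C(=N\C(=O)c1ccco1)NC(=O)c1ccco1`, which gives 30 nM, and far from compound 1, `CS/C(=N\C(=O)c1ccno1)NC(=O)c1ccno1`, which gives 77800 nM. Compound 3 thus stands as the most potent of the three.

Compound 4, `CS/C(=N\C(=O)c1cccs1)NC(=O)c1cccs1`, has not yet been measured. It differs from compound 3 in one place: a group of 2 heavy atoms (1 carbon, 1 sulfur; no ring) in place of a group of 2 heavy atoms (1 carbon, 1 selenium; no ring), on a carbon with a double bond to nitrogen.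

Among the compounds with values here, no pair of measured compounds differs in exactly this way. Within the data shown here, compound 1 is the only compound carrying methylsulfanyl, but it also carries other rings, so its value alone does not isolate the swap. Still, the weak result of compound 1 in this assay, 77800 nM, is the only hint available. Compound 4 is therefore expected to be weaker than compound 3, with a step of a 150-fold higher number from compound 3 to compound 4 (2.17 log units; beyond the scatter), and an estimated value of 500 nM, within a range from 30 nM to 20000 nM.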

Compound 4, concentration for 50% growth inhibition: 44500 nM
Compound 4: middle estimate off by 89-fold (1.95 log units), on the low side; measured number above the stated range.
By their numbers in this assay, from the lowest: compound 3; then compound 2; then compounds 4 and 1 (each within the scatter of the next).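

In this assay the change from the group holding selenium to methylsulfanyl, on a carbon with a double bond to nitrogen whose other neighbours are amide-type nitrogens, produces a 13000-fold higher number from compound 3 to compound 4 (4.12 log units; beyond the scatter) in a single step. Going by these compounds alone, with the rest of the molecule unchanged, this one place therefore decides most of the potency of compound 3, which the earlier compounds could not show, since compound 1 and compound 2 differ in their rings as well as in this atom. Nothing measured here explains why this exchange matters so much.

Within the data shown here, this is the only pair that isolates the swap, so whether the step would be as large on the core of compound 2 stays open. Also open, going by these compounds, is how a longer chain on the selenium, such as ethyl, or an amine on this carbon would read.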